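The source may report more compounds than this note shows. Statements on the series, on what has been measured and on what is new or still open speak of the compounds shown alone.

Compound 2 `COc1cccc(-c2cc(=O)c3cc(N)ccc3o2)c1` gives 247000 nM in an ADME assay on MT4 cells (Homo sapiens) for cytotoxicity, read by MTT assay, with a stated time of 4 days; a lower number here means that less compound is tolerated, a higher number that more compound is tolerated. Compound 3 `Nc1ccc2oc(-c3cccc(C(F)(F)F)c3)cc(=O)c2c1` gives 138000 nM, and these two numbers, the only ones in the series, lie within the scatter of each other. Compound 1 `COc1cccc(-c2cc(=O)c3cc(NC(C)=O)ccc3o2)c1` is recorded at > 404000 nM, which is a limit and not a number.

Compound 4 `COc1cccc(-c2oc3ccc(N)cc3c(=O)c2O)c1` carries one change from compound 2: hydroxy in place of hydrogen on an aromatic carbon. Two measured steps give the scale, an at least 1.6-fold lower number from compound 1 to compound 2 (0.21 log units; that floor lies within the scatter) and a 1.8-fold lower number from compound 2 to compound 3 (0.25 log units; within the scatter). Both changed other places on the molecule, so neither tests this carbon directly, and they bear on the new step only as a guide to its size. With both steps within the scatter, no step beyond the scatter is expected in this assay, with a slight lean towards a lower number. The estimated step is a 1.9-fold lower number from compound 2 to compound 4 (0.28 log units; within the scatter). For compound 4 the estimate is 130000 nM, with an expected range of 45000 nM to 320000 nM.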

Compound 4, half-maximal cytotoxic concentration: 40800 nM
Compound 4: middle estimate off by 3.2-fold (0.50 log units), on the high side, and the stated range ends above it.
By their numbers in this assay, from the lowest: compound 4; then compounds 3 and 2 (each within the scatter of the next). At a limit, above all of these: compound 1.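

Hydroxy in place of hydrogen on this aromatic carbon, two atoms from the ring oxygen, gives the first step in the series that lies beyond the scatter: a 6.1-fold lower number from compound 2 to compound 4 (0.78 log units; beyond the scatter) in this assay. The two earlier steps changed other places and stayed within the scatter, so this carbon is the one place shown where a change of a single heavy atom clearly lowers the tolerated concentration. Compound 1 alone stands at a limit, which does not touch this step: the limit of > 404000 nM in this assay, at which 1 of the 4 values shown sits.

From the compounds shown here alone, the step rests on one pair, so it remains open whether it belongs to hydroxy itself or would also follow from a fluorine, an amine or a methyl ether on the same carbon. Also open, going by these compounds, is whether it holds with trifluoromethyl in place of methoxy, or with acetyl on the nitrogen.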